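Amine substituents on a shared core: a cyclobutylmethyl variant

The source may report more compounds than this note shows. Statements on the series, on what has been measured and on what is new or still open speak of the compounds shown alone.

Compound 2 `C=C(C)CN(CC)Cc1c(C(F)(F)F)nc2n(-c3c(C)cc(C)cc3C)c(Cl)cn12` holds the lowest of the two numbers recorded in an assay on cells for displacement of a labelled ligand from corticotropin-releasing factor receptor 1 (Homo sapiens), with a stated time of 100 min; on this read-out lower numbers stand for stronger inhibition and higher numbers for weaker inhibition; in this assay compound 2 gives 67 nM. For the measured compounds named here, its only measured neighbour, compound 1 `CCCCN(C)Cc1c(C(F)(F)F)nc2n(-c3c(C)cc(C)cc3C)c(Cl)cn12`, gives 310 nM, and the change of both groups on the amine nitrogen brought a 4.6-fold lower number from compound 1 to compound 2 (0.67 log units; beyond the scatter). Compound 3 `CCCN(Cc1c(C(F)(F)F)nc2n(-c3c(C)cc(C)cc3C)c(Cl)cn12)CC1CCC1` has not yet been measured. It differs from compound 2 in one place: (cyclobutylmethyl)(propyl)amino in place of ethyl(2-methylprop-2-en-1-yl)amino on a saturated chain carbon bound to an aromatic carbon. Going by the values given here, the single measured step that bears on this change, a 4.6-fold lower number from compound 1 to compound 2 (0.67 log units; beyond the scatter), shows that the two groups on the amine nitrogen can move the number by a modest amount, but no measured compound carries a ring on this amine, so the direction for compound 3 remains open. Relative to compound 2, compound 3 is expected to show a step of a 1.3-fold lower number from compound 2 to compound 3 (0.13 log units; within the scatter). The value of compound 3 is estimated at 50 nM, within a range of 15 nM to 200 nM.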

Compound 3, inhibition constant: 5.3 nM
For compound 3 the middle estimate is 9.4-fold (0.97 log units) above the measured one, and the stated range ends above it.
By their numbers in this assay, from the lowest: compound 3; then compound 2; then compound 1.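

In this assay, the groups on the amine nitrogen turn out to move the number much further than the earlier pair showed. (Cyclobutylmethyl)(propyl)amino in place of ethyl(2-methylprop-2-en-1-yl)amino gives a 13-fold lower number from compound 2 to compound 3 (1.10 log units; beyond the scatter) and in place of butyl(methyl)amino gives a 58-fold lower number from compound 1 to compound 3 (1.77 log units; beyond the scatter) at the same position, both large steps. Compound 3, the only one of the three with a ring on this amine, holds the lowest number, and no evidence is available on what lies behind this drop.

On these data alone, both groups on the nitrogen differ in each step, and the share of the cyclobutylmethyl group and of the propyl chain remains open. Also open, as far as these compounds go, is how a cyclopropylmethyl or cyclopentylmethyl group, or a butyl chain paired with cyclobutylmethyl, would read at this position.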